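A few compounds are considered here, and "the series" means these few. Any claim that something is new, unique, unknown or untested is made for them only; others in the source may bear on it.

Compound 3 `NCc1ccc(C(=O)Nc2ccncc2F)cc1-c1cccc(C(=O)OC2CCCOC2)c1` is assessed in an assay on isolated protein for inhibition of Rho-associated protein kinase 2 (Homo sapiens), read by radiometric assay (a higher number here means a weaker inhibitor, a lower number a stronger inhibitor), where compound 3 gives 8.7 nM. Among the three compounds that share its core, compound 3 stands second highest: its nearest neighbour is compound 1 `NCc1ccc(C(=O)Nc2ccncc2F)cc1-c1cccc(C(=O)Oc2ccccc2)c1`, which in this assay gives 6.2 nM, and the step of a 1.4-fold higher number from compound 1 to compound 3 (0.15 log units; within the scatter) lies within the scatter. The furthest is compound 2 `NCc1ccc(C(=O)Nc2ccncc2F)cc1-c1cccc(C(=O)O)c1`, which gives 55 nM, separated by the step of a 6.3-fold lower number from compound 2 to compound 3 (0.80 log units; beyond the scatter). The step of an 8.9-fold higher number from compound 1 to compound 2 (0.95 log units; beyond the scatter) is of similar size.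

Compound 4 `NCc1ccc(C(=O)Nc2ccncc2F)cc1-c1cccc(C(=O)OCC2CCCC2)c1` is reached from compound 3 by one change: cyclopentylmethyl in place of oxan-3-yl on an oxygen next to a carbonyl group. Going by the values given here, the steps that bear on it are those on the same oxygen next to the carbonyl group. Replacing phenyl with oxan-3-yl, from compound 1 to compound 3, left the number within the scatter, whereas replacing hydrogen with either group moved it by a modest amount. Compound 4 keeps a six-heavy-atom group on that oxygen, so the step into compound 4 is expected to stay within the scatter, without a clear direction. Accordingly, compound 4 is estimated to give 8 nM, with a range from 3 nM to 20 nM, which corresponds to an expected step of a 1.1-fold lower number from compound 3 to compound 4 (0.04 log units; within the scatter).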

Compound 4, half-maximal inhibitory concentration: 13 nM
Compound 4: middle estimate off by 1.6-fold (0.21 log units), on the low side; the range from low to high includes it.
By their numbers in this assay, from the lowest: compounds 1, 3 and 4 (each within the scatter of the next, the first and the last beyond it); then compound 2.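

In this assay, replacing oxan-3-yl with cyclopentylmethyl gives a 1.5-fold higher number from compound 3 to compound 4 (0.17 log units; within the scatter) and thus removes the ring oxygen and the hydrogen-bond acceptor it counts as, with the number of heavy atoms unchanged and no readable effect at this oxygen next to a carbonyl group. Against the parent with hydrogen on this oxygen, the all-carbon group gives a 4.2-fold lower number from compound 2 to compound 4 (0.63 log units; beyond the scatter) and so joins phenyl and oxan-3-yl among the groups whose numbers lie beyond the scatter of compound 2. Against phenyl, it gives a 2.1-fold higher number from compound 1 to compound 4 (0.32 log units; beyond the scatter) and so provides the first difference between two groups larger than hydrogen at this place that passes the scatter, although compound 3 lies within the scatter of both compound 1 and compound 4.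

The compounds shown leave open whether a straight alkyl chain or a group carrying an amine on this oxygen would fall among these esters or nearer compound 2. They also leave open whether an amide in place of the ester would keep these numbers. No measurement shown offers an explanation for these steps.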